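The source may report more compounds than this note shows. Statements on the series, on what has been measured and on what is new or still open speak of the compounds shown alone.

Measured so far, in an assay on HEK-293T cells for inhibition of phospholipase A and acyltransferase 4 (Homo sapiens), with stated times of 30 min and 20 min; on this read-out lower numbers stand for stronger inhibition and higher numbers for weaker inhibition:
- compound 1 `O=C(NCc1ccccc1)C(F)(F)C(O)CCc1ccccc1`: > 10000 nM, a limit of the assay
- compound 2 `O=C(CCc1ccccc1)C(F)(F)C(=O)NCc1ccccc1`: > 10000 nM, a limit of the assay
- compound 3 `O=C(CCc1ccccc1)[C@H](F)C(=O)NCc1ccccc1`: > 10000 nM, a limit of the assay

Compound 3 stands nowhere in particular on these numbers. In this assay compound 3 gives only > 10000 nM, which is a limit and not a number. Among the compounds with values here, the same holds for the other two members: the limit of > 10000 nM in this assay, at which 3 of the 3 values shown sit, so no ordering among compounds 1, 2 and 3 can be read from this assay, and no step between measured compounds can be stated.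

Compound 4 `O=C(CCc1ccccc1)CC(=O)NCc1ccccc1` has not been measured. It differs from compound 3 in one place: hydrogen in place of fluoro on a saturated chain carbon bound to two carbonyl carbons. The compounds 1, 2 and 3 share the amide and the phenylpropanoyl part with compound 4, and all three are at the limit; taking the fluoro away from the saturated chain carbon bound to two carbonyl carbons leaves the rest of compound 3 untouched.

No step beyond the scatter is expected from compound 3 to compound 4 in this assay, since compound 3 is itself only at the limit and the step that the limit leaves unreadable from compound 3 to compound 4 is estimated as essentially none. Compound 4 is therefore expected to give about 20000 nM in this assay, within 8000 nM to 60000 nM, most likely again reported only as a limit.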

Compound 4, half-maximal inhibitory concentration: > 10000 nM
Compound 4: no number, only a limit; the forecaster's own chance of this, stated with the estimate: 85%; the middle value does not contradict the limit.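

No step can be read from compound 3 to compound 4 in this assay, since both compounds stand only at a limit: the limit of > 10000 nM in this assay, at which 4 of the 4 values shown sit.

The compounds shown leave open how compounds 1 to 4 rank among themselves in this assay, and which change to the shared core, if any, would give a measurable inhibition.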